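The source may hold more compounds than are shown below. What is called first, only, known or untested is meant among the compounds shown, and "the series" means these compounds.

Measured so far: compound 1 `c1ccc(N2N=NCC2c2ccncc2)cc1` gives 107 mg/kg in a functional assay on the whole organism with Mus musculus as the target; a higher number here means that more compound is needed for the effect, a lower number that less compound is needed; compound 2 `c1ccc(-n2nncc2-c2cccnc2)cc1` gives 39.7 mg/kg in this assay.

Of these two compounds, compound 2 stands at the lowest number in this assay, and the nearest value, that of compound 1, lies above it by a gap beyond the usual scatter. From compound 2 the account moves on to compound 3 `Brc1ccc(-n2nncc2-c2cccnc2)cc1`, which has not yet been measured in this assay. The structural change is bromo in place of hydrogen on an aromatic carbon. For the measured compounds named here, no pair of measured compounds shows a change of this kind, so the size of the step cannot be read from the data and rests on expectation alone. A step no larger than the scatter is expected, with no clear direction, and it is estimated as a 1.1-fold lower number from compound 2 to compound 3 (0.05 log units; within the scatter). Compound 3 is accordingly expected to give about 35 mg/kg in this assay, within a range from 15 mg/kg to 90 mg/kg.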

Compound 3, dose for half-maximal effect: 40.7 mg/kg
Compound 3: middle estimate off by 1.2-fold (0.07 log units), on the low side; the measured number falls inside the stated range.
By their numbers in this assay, from the lowest: compounds 2 and 3 (each within the scatter of the next); then compound 1.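

Bromo in place of hydrogen, on an aromatic carbon of the six-membered aromatic ring of carbon only and para to a large group, gives the first reading of any change at this position: in this assay the step is a 1.0-fold higher number from compound 2 to compound 3 (0.01 log units; within the scatter). A single bromine atom can therefore stand at this place on the shared core without moving the number beyond the scatter, so this position accepts at least one heavy atom in this whole-organism read-out. No measurement at hand bears on what lies behind this result.

As far as these compounds go, whether the same holds for other groups at this place, such as an amine, a carboxylic acid or a longer chain, stays open. So does the question of whether bromo would behave alike on the other carbons of this ring.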